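The source may report more compounds than this note shows. Statements on the series, on what has been measured and on what is new or still open speak of the compounds shown alone.

Compound 2 `CC1(C)Oc2ccc(C(=O)Cc3ccccc3)cc2[C@@H](/N=C(\NC#N)Nc2ccc(Cl)cc2)[C@@H]1O` gives 6800 nM in a functional assay (aorta) with Rattus norvegicus as the target (a higher number here means a weaker inhibitor, a lower number a stronger inhibitor), the lowest of the three numbers shown, although compound 1 `CC1(C)Oc2ccc(C(=O)c3ccccc3)cc2[C@@H](/N=C(\NC#N)Nc2ccc(Cl)cc2)[C@@H]1O` with 7100 nM and compound 3 `CC1(C)Oc2ccc(Cc3ccccc3)cc2[C@@H](/N=C(\NC#N)Nc2ccc(Cl)cc2)[C@@H]1O` with 10000 nM both lie within the scatter of it. Compound 4 `C=C(c1ccccc1)c1ccc2c(c1)[C@@H](/N=C(\NC#N)Nc1ccc(Cl)cc1)[C@H](O)C(C)(C)O2` is reached from compound 2 by 1-phenylethenyl in place of benzylcarbonyl on an aromatic carbon. The step that bears most on this is the one that also removed the carbonyl from compound 2, namely a 1.5-fold higher number from compound 2 to compound 3 (0.17 log units; within the scatter), and the steps of a 1.0-fold lower number from compound 1 to compound 2 (0.02 log units; within the scatter) and a 1.4-fold higher number from compound 1 to compound 3 (0.15 log units; within the scatter) were equally small. The change in this assay is therefore expected to stay within the scatter, as a 1.3-fold higher number from compound 2 to compound 4 (0.12 log units; within the scatter). Compound 4 is estimated at 9000 nM, within a range from 4000 nM to 20000 nM.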

Compound 4, half-maximal inhibitory concentration: 10700 nM
For compound 4 the middle estimate is 1.2-fold (0.08 log units) below the measured one; the range from low to high includes it.
By their numbers in this assay, from the lowest: compounds 2, 1, 3 and 4 (each within the scatter of the next).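

Compound 4 shows that this aromatic carbon also accepts 1-phenylethenyl, a group with no hydrogen-bond acceptor, with every step in this assay staying within the scatter: a 1.6-fold higher number from compound 2 to compound 4 (0.20 log units; within the scatter) and a 1.5-fold higher number from compound 1 to compound 4 (0.18 log units; within the scatter) and a 1.1-fold higher number from compound 3 to compound 4 (0.03 log units; within the scatter). Benzoyl, benzylcarbonyl, benzyl and 1-phenylethenyl therefore cannot be told apart here. No measurement accompanies these values that could explain them. As far as these compounds go, it remains open whether an amine or a carboxylic acid at this carbon, or a methoxy group carrying no phenyl ring, would move the number beyond the scatter.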